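The source may report more compounds than this note shows. Statements on the series, on what has been measured and on what is new or still open speak of the compounds shown alone.

Measured so far:
- compound 1, `CCOC(=O)[C@H](CCC(=O)O)NC(=O)c1ccc(CNc2nc3cc(N)cc(N)c3nc2-c2ccccc2)cc1`: < 100000 nM
- compound 2, `COc1ccc(CNc2nc3cc(N)cc(N)c3nc2-c2ccccc2)cc1OC`: 29500 nM
- compound 3, `COc1cc(CNc2nc3cc(N)cc(N)c3nc2-c2ccccc2)cc(OC)c1OC`: 15100 nM

In a functional assay on MDA-MB-231 cells (Homo sapiens) for inhibition, read by sulforhodamine B assay, with a stated time of 48 h (a lower number here means a stronger inhibitor of growth, a higher number a weaker inhibitor of growth), compound 1 gives only a limit, < 100000 nM. Compound 2 gives 29500 nM and compound 3 gives 15100 nM, so compound 2 has the highest of the two numbers given, yet the step of a 2.0-fold lower number from compound 2 to compound 3 (0.29 log units; within the scatter) stays within the scatter.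

Compound 4, `COc1ccc(CNc2nc3cc(N)cc(N)c3nc2-c2ccccc2)cc1`, differs from compound 2 by hydrogen in place of methoxy on an aromatic carbon. Among the measured compounds shown here, the only measured step that bears on this is a 2.0-fold lower number from compound 2 to compound 3 (0.29 log units; within the scatter), where a methoxy was added rather than removed; since that addition changed nothing beyond the scatter, removing one is also expected to leave the number within the scatter, in no particular direction. Compound 4 is therefore estimated at 35000 nM, between 15000 nM and 80000 nM. The expected step is a 1.2-fold higher number from compound 2 to compound 4 (0.07 log units; within the scatter).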

Compound 4, concentration for total growth inhibition: 13800 nM
Estimate against measurement, compound 4: 2.5-fold (0.40 log units) above; the whole stated range lies above it.
By their numbers in this assay, from the lowest: compounds 4, 3 and 2 (each within the scatter of the next, the first and the last beyond it).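

In this assay, among the compounds shown here, going from the 3,4-dimethoxyphenyl group to the 4-methoxyphenyl group gives a 2.1-fold lower number from compound 2 to compound 4 (0.33 log units; beyond the scatter), the first change on this ring whose step passes the scatter. Taking away the methoxy that sits ortho to a methoxy group therefore did not cost growth inhibition here; the number fell. Nothing measured here accounts for this step.

The compounds shown leave open what a hydroxyl group, an amine or a fluorine atom would do at this position. On these data alone, a longer chain on the oxygen there also remains untested in this set.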